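The source may report more compounds than this note shows. Statements on the series, on what has been measured and on what is new or still open speak of the compounds shown alone.

Compound 1 `O=C(C1CC12CCC2)N1CCc2nc(C#Cc3ccccc3)sc2C1` was tested in an assay on HEK293 cells for negative allosteric modulation of metabotropic glutamate receptor 5 (Homo sapiens), read by FLIPR, with a stated time of 1 h; on this read-out higher numbers stand for weaker inhibition and lower numbers for stronger inhibition. In this assay compound 1 gives > 10000 nM, which is a limit of the assay rather than a measured number. Compound 2 `O=C(C1CC(F)(F)C1)N1CCc2nc(C#Cc3cccc(F)c3)sc2C1` is a relative that differs from compound 1 in two places. In this assay compound 2 gives > 10000 nM, again only a limit. Going by the values given here, both measured values therefore sit at the limit of > 10000 nM in this assay, at which 2 of the 2 values shown sit, so compound 1 stands at the weak edge of what this assay can resolve, with no measured compound to compare it against in a single step.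

Compound 3 `O=C(N1CCC(F)CC1)N1CCc2nc(C#Cc3ccccc3)sc2C1` differs from compound 1 in one place: a group of 7 heavy atoms (5 carbon, 1 nitrogen, 1 fluorine; one six-membered non-aromatic ring with 1 hetero atom) in place of a group of 6 heavy atoms (6 carbon; one three-membered non-aromatic ring of carbon only, one four-membered non-aromatic ring of carbon only), on a carbonyl carbon. Among the compounds with values here, since no measured step of any kind is available here, the step from compound 1 to compound 3 is expected to be none beyond the scatter, which is what a step that the limit leaves unreadable from compound 1 to compound 3 means. Compound 3 is estimated at 12000 nM, within a range from 3000 nM to 50000 nM.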

Compound 3, half-maximal inhibitory concentration: > 10000 nM
Compound 3: a limit, no number; the forecaster's own chance of this, stated with the estimate: 70%; the middle value is on the limit's open side.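

Compound 1 and compound 3 both give only a limit in this assay, so the step between them cannot be read. The compounds shown leave open how far each lies past that limit, and whether any change to the shared core's amide group gives a measurable value: the limit of > 10000 nM in this assay, at which 3 of the 3 values shown sit.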